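This account rests on a few compounds, and the source may have more. Where it says the series, first, only, none or still open, it means among the compounds named here.

Measured so far in this series:

compound 1, `O=C(Nc1cccc(N2CCCC2=O)c1)C1CCCN(C(=O)c2cc(C(F)(F)F)cc(C(F)(F)F)c2)C1`: 0%
compound 2, `O=C(Nc1cccc(Cc2ccccc2)c1)C1CCCN(C(=O)c2cc(C(F)(F)F)cc(C(F)(F)F)c2)C1`: 0%
compound 3, `O=C(Nc1ccc(Cl)cc1)C1CCCN(C(=O)c2cc(C(F)(F)F)cc(C(F)(F)F)c2)C1`: 14%

All three numbers come from an ADME assay on PC-3 cells (Homo sapiens) for cytotoxicity, read by WST assay, tested at 100 uM; a lower number here means less inhibition, a higher number more inhibition at the concentration tested (going by the name of the read-out). Compound 3 stands highest of the three: a number 14 percentage points higher from compound 1 to compound 3 (beyond the scatter), and compound 2 sits where compound 1 does, no change at the digits printed from compound 1 to compound 2 (within the scatter). The whole spread of the series is therefore one modest step.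

Compound 4, `C=CCOc1cccc(NC(=O)C2CCCN(C(=O)c3cc(C(F)(F)F)cc(C(F)(F)F)c3)C2)c1`, follows from compound 3 by the change (3-(allyloxy)phenyl in place of 4-chlorophenyl on an amide-type nitrogen).

Going by the values given here, two measured steps touch the group on the amide-type nitrogen. The exchange of the whole aryl there, a number 14 percentage points higher from compound 1 to compound 3 (beyond the scatter), moved the number modestly; the exchange of a substituent on that aryl, no change at the digits printed from compound 1 to compound 2 (within the scatter), moved nothing beyond the scatter. Among the compounds with values here, no measured compound carries an allyloxy group or any ether, so the new group has no direct precedent here. Within the data shown here, since compound 3 holds the only number above zero and every other aryl on this nitrogen gave zero, the step to compound 4 is expected to be small and, if anything, downward: a number 9 percentage points lower from compound 3 to compound 4 (within the scatter).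

Compound 4 is estimated at 5%, in the range 0% to 20%.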

Compound 4, a percentage reported as inhibition, at one concentration (the size of the read-out at that concentration, not a potency): 0%
Beside the measured number, compound 4's estimate is 5 percentage points above it; the range from low to high includes it.
By their numbers in this assay, from the lowest: compounds 1, 2 and 4 (each within the scatter of the next); then compound 3.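

In this assay, allyloxy on the aryl reads the same as the two other substituents tried there (benzyl: no change at the digits printed from compound 2 to compound 4 (within the scatter); 2-oxopyrrolidin-1-yl: no change at the digits printed from compound 1 to compound 4 (within the scatter)), so three different substituents on this aryl now give one shared reading. The exchange away from 4-chlorophenyl (a number 14 percentage points lower from compound 3 to compound 4 (beyond the scatter)) sets compound 3 apart from a third compound, and it is now the only one of the four whose steps to all the others lie beyond the scatter, though each of those steps is modest. No measured evidence bears on what lies behind this difference between compound 3 and the other three.

As far as these compounds go, the reading of an unsubstituted phenyl or a 3-chlorophenyl on this amide-type nitrogen remains open, so the step cannot yet be assigned either to the chlorine itself or to where it sits on the ring. Also open, from the compounds shown here alone, is how an amine or a carboxylic acid on this aryl would read on the same shared core, and whether any other halogen, such as fluorine or bromine, would follow compound 3 or the other three.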